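This account rests on a few compounds, and the source may have more. Where it says the series, first, only, none or still open, it means among the compounds named here.

Of the compounds shown here, three built on one shared core have been measured in an assay on HeLa cells for inhibition of Indoleamine 2,3-dioxygenase 1 (Homo sapiens), with a stated time of 48 h; a higher number here means a weaker inhibitor, a lower number a stronger inhibitor. Compound 1 `COCCNc1nonc1/C(=N/O)Nc1ccc(F)c(Br)c1` gives 100 nM. Compound 2 `NCCNc1nonc1/C(=N/O)Nc1ccc(F)c(Br)c1` gives 98 nM. Compound 3 `CC(=O)NCCNc1nonc1/C(=N/O)Nc1ccc(F)c(Br)c1` gives 17 nM, the lowest of the three numbers; its gap to compound 2 and to compound 1 lies beyond the scatter, whereas the values of compound 1 and compound 2 sit within the scatter of each other. The steps of a 5.9-fold lower number from compound 1 to compound 3 (0.77 log units; beyond the scatter) and a 5.8-fold lower number from compound 2 to compound 3 (0.76 log units; beyond the scatter) both point the same way: placing an acetyl group on the amine nitrogen gave a modestly stronger inhibitor.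

Compound 4 `CS(=O)(=O)NCCNc1nonc1/C(=N/O)Nc1ccc(F)c(Br)c1` has not yet been measured. It differs from compound 3 in one place: methylsulfonyl in place of acetyl on an amine nitrogen. Among the compounds with values here, no measured step exchanges one such cap for another; the nearest evidence is a 5.8-fold lower number from compound 2 to compound 3 (0.76 log units; beyond the scatter), which shows that a cap on that nitrogen matters. With the cap kept, the number is expected to stay close to that of compound 3, without a step beyond the scatter in this assay. Compound 4 is therefore estimated at 25 nM, with a range from 8 nM to 80 nM. The expected step is a 1.5-fold higher number from compound 3 to compound 4 (0.17 log units; within the scatter).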

Compound 4, half-maximal inhibitory concentration: 16 nM
Beside the measured number, compound 4's estimate is 1.6-fold (0.19 log units) above it; low and high end bracket the measured number.
By their numbers in this assay, from the lowest: compounds 4 and 3 (each within the scatter of the next); then compounds 2 and 1 (each within the scatter of the next).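

Swapping acetyl for methylsulfonyl on the amine nitrogen leaves the number in this assay essentially unchanged (a 1.1-fold lower number from compound 3 to compound 4 (0.03 log units; within the scatter)), so this position accepts a sulfonyl cap as well as a carbonyl one. The gain over the uncapped amine therefore does not belong to acetyl alone: methylsulfonyl also gives a modest step (a 6.1-fold lower number from compound 2 to compound 4 (0.79 log units; beyond the scatter)), and the step from the methoxy compound is of similar size (a 6.3-fold lower number from compound 1 to compound 4 (0.80 log units; beyond the scatter)). Nothing available explains why the two caps read alike.

On these data alone, it remains open whether a bulkier cap, such as benzoyl or phenylsulfonyl, or a urea, would hold the number at this level. Also open, as far as these compounds go, is whether either cap would behave the same way on a longer chain, such as 3-acetamidopropyl in place of 2-acetamidoethyl.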